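A few compounds are considered here, and "the series" means these few. Any claim that something is new, unique, unknown or untested is made for them only; others in the source may bear on it.

Measured so far:
compound 1 `COc1ccc(/C=C/C2CC(=O)C=CO2)cc1OC` gives 146 uM
compound 2 `COc1cc(/C=C/C2CC(=O)C=CO2)cc(OC)c1OC` gives 223 uM
compound 3 `O=c1ccoc(/C=C/c2ccccc2)c1` gives 514 uM

In a functional assay on NCI/ADR cells (Homo sapiens) for inhibition, read by sulforhodamine B assay, with a stated time of 48 h (a lower number here means a stronger inhibitor of growth, a higher number a weaker inhibitor of growth), compound 2 stands second highest of the three numbers: compound 1 sits within the scatter of it, while compound 3 lies beyond the scatter on the higher side. Compound 4 `COc1cc(/C=C/C2CC=CC(=O)N2)cc(OC)c1OC` differs from compound 2 by a group of 7 heavy atoms (5 carbon, 1 nitrogen, 1 oxygen; one six-membered non-aromatic ring with 1 hetero atom) in place of a group of 7 heavy atoms (5 carbon, 2 oxygen; one six-membered non-aromatic ring with 1 hetero atom), on a double-bonded chain carbon bound to a double-bonded chain carbon. Among the measured compounds shown here, the only measured step, a 1.5-fold higher number from compound 1 to compound 2 (0.18 log units; within the scatter), concerns a methoxy group on the aromatic ring and says nothing about exchanging one six-membered ring for another; the step from compound 2 to compound 3 removes three methoxy groups and is likewise a different change. For the measured compounds named here, with no step of this kind available, the expectation rests on compound 2 alone, and the estimated step of a 1.1-fold higher number from compound 2 to compound 4 (0.05 log units; within the scatter) is held close to none beyond the scatter, with a wide range. Compound 4 is therefore expected to give about 250 uM, between 90 uM and 700 uM.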

Compound 4, concentration for growth inhibition (reported as GI): > 864 uM
Compound 4: only a limit was reported; the forecaster's own chance of this, stated with the estimate: 20%; at least 3.4-fold (0.53 log units) between middle value and limit.
By their numbers in this assay, from the lowest: compounds 1 and 2 (each within the scatter of the next); then compound 3. At a limit, above all of these: compound 4.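

In this assay, exchanging the group on the double-bonded chain carbon gives an at least 3.8-fold higher number from compound 2 to compound 4 (0.58 log units; beyond the scatter), the first change shown that reaches beyond the scatter. The two groups have equal heavy-atom counts, yet swapping 1 oxygen for 1 nitrogen and adding 1 hydrogen-bond donor clearly weakens growth inhibition. Compound 4 is reported only as a limit: the limit of > 864 uM in this assay, at which 1 of the 4 values shown sits.

On these data alone, whether the same exchange would act alike on compound 1 or compound 3 stays open. So does whether an amine or a carboxylic acid at this place would give a number closer to that of compound 2.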